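Swapping the Fluorophenyl Ketone for a Trimethoxyphenyl Ketone

A few compounds are considered here, and "the series" means these few. Any claim that something is new, unique, unknown or untested is made for them only; others in the source may bear on it.

Compound 1, `COc1cc(-c2nnc3n2NC(c2cccs2)C(C(=O)c2ccc(C)cc2)S3)cc(OC)c1OC`, gives 28400 nM.
Compound 2, `COc1cc(-c2nnc3n2NC(c2cccs2)C(C(=O)c2ccccc2)S3)cc(OC)c1OC`, reaches only the limit of the assay, > 100000 nM.
Compound 3, `COc1cc(-c2nnc3n2NC(c2cccs2)C(C(=O)c2ccc(F)cc2)S3)cc(OC)c1OC`, gives 43700 nM.

These three compounds share one core and differ only in the aromatic ring attached to the carbonyl carbon. In a functional assay on MCF7 cells (Homo sapiens) for cytotoxicity, read by MTT assay, with a stated time of 48 h (a lower number here means a stronger inhibitor, a higher number a weaker inhibitor), compound 3 stands at the higher end of the two numbers given; its nearest neighbour is compound 1, and the step of a 1.5-fold higher number from compound 1 to compound 3 (0.19 log units; within the scatter) lies within the scatter. The step of an at least 3.5-fold higher number from compound 1 to compound 2 (0.54 log units; beyond the scatter) and the step of an at least 2.2-fold lower number from compound 2 to compound 3 (0.35 log units; beyond the scatter) both reach beyond it, with compound 2 sitting at the limit of > 100000 nM in this assay, at which 1 of the 3 values shown sits.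

Compound 4, `COc1cc(C(=O)C2Sc3nnc(-c4cc(OC)c(OC)c(OC)c4)n3NC2c2cccs2)cc(OC)c1OC`, carries a different ring at that position: 3,4,5-trimethoxyphenyl in place of 4-fluorophenyl on a carbonyl carbon. Within the data shown here, none of the measured steps replaces one aromatic ring by another of a different size; they only exchange a single small group on the same ring, and even those exchanges moved this assay by modest amounts. The size and direction of the step to compound 4 are thus open. A step of a 1.1-fold lower number from compound 3 to compound 4 (0.04 log units; within the scatter) is estimated for compound 4, with an expected value of 40000 nM, between 10000 nM and 150000 nM.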

Compound 4, half-maximal inhibitory concentration: 71000 nM
Compound 4: the middle estimate sits 1.8-fold (0.25 log units) below what was measured, within the range that was stated.
By their numbers in this assay, from the lowest: compounds 1, 3 and 4 (each within the scatter of the next, the first and the last beyond it). At a limit, above all of these: compound 2.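

In this assay, among these compounds, the earlier steps only exchanged one small group on the ring, whereas here a group of 12 heavy atoms replaces one of 7 on the carbonyl carbon, and a 1.6-fold higher number from compound 3 to compound 4 (0.21 log units; within the scatter) shows that this larger exchange still stays within the scatter. Measured against 4-methylphenyl, the same ring does make a difference, with a 2.5-fold higher number from compound 1 to compound 4 (0.40 log units; beyond the scatter), so compound 4 is modestly weaker than compound 1. The step from phenyl gives only a floor, an at least 1.4-fold lower number from compound 2 to compound 4 (0.14 log units; that floor lies within the scatter), and compound 2 stands at a limit of the assay: the limit of > 100000 nM in this assay, at which 1 of the 4 values shown sits.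

As far as these compounds go, how an amine, a carboxylic acid or an ethyl group in place of the methyl of compound 1 would read in this assay remains open. The compounds shown also cannot separate the size of 3,4,5-trimethoxyphenyl from the contribution of its oxygen atoms.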